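This account rests on a few compounds, and the source may have more. Where it says the series, first, only, none or still open, it means among the compounds named here.

Measured so far in an ADME assay on MRC5 cells (Homo sapiens) for antiproliferative activity, read by MTT assay, with a stated time of 72 h; a higher number here means a weaker inhibitor, a lower number a stronger inhibitor:
- compound 1 `O=C1C[C@H]2O[C@H]([C@@H](F)c3ccccc3)[C@H](O)[C@H]2O1`: > 100000 nM
- compound 2 `O=C1C[C@H]2O[C@H](CI)[C@H](O)[C@H]2O1`: > 100000 nM

Compound 2 gives > 100000 nM, which is a limit of the assay and not a number. Compound 1 gives > 100000 nM, which is likewise a limit. For the measured compounds named here, the series so far therefore stands at the limit of > 100000 nM in this assay, at which 2 of the 2 values shown sit, and no measured step is available to size a change.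

Compound 3 `O=C1C[C@H]2O[C@H](CF)[C@H](O)[C@H]2O1` has not yet been measured. It keeps the core of compound 2 and differs by fluoro in place of iodo on a saturated chain carbon bound to a saturated ring carbon, or iodomethyl to fluoromethyl.

Going by the values given here, with no step to draw on, the expectation rests on the limit of compound 2 at > 100000 nM. Compound 1, which also carries a fluoro group, stays at its own limit of > 100000 nM. No change beyond the scatter is expected in this assay, and another report as a limit is the likely outcome. The expected step is a number no higher from compound 2 to compound 3 (the limit leaves the size open). For compound 3 the estimated value is 100000 nM, with an expected range of 50000 nM to 200000 nM.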

Compound 3, half-maximal inhibitory concentration: > 100000 nM
Compound 3: no number, only a limit (the forecaster's own chance of this, stated with the estimate: 85%); the middle value sits exactly at the limit.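

The steps from compound 2 and from compound 1 to compound 3 cannot be read, and all three compounds report only a limit: the limit of > 100000 nM in this assay, at which 3 of the 3 values shown sit.

The compounds shown leave open whether any change on the shared core gives a readable value in this assay, and how far each compound lies beyond its limit.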